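Swapping Hydroxymethyl for Methylcarbamoyl on a Shared Core

The compounds below may be only part of what the source reports. "The series", "measured", "known", "first", "only" and "open" are said of these compounds alone.

Four compounds share one bridged core and differ at two places. Compound 1 `Nc1ncnc2c1ncn2[C@@H]1O[C@@]2(CO)CN[C@@H]1[C@@H]2O` and compound 2 `CNC(=O)[C@@]12CN[C@@H]([C@H](n3cnc4c(N)ncnc43)O1)[C@@H]2O` are the two simplest members. In a functional assay for agonist activity at adenosine receptor A1 (Homo sapiens) (a higher number here means that more compound is needed for the effect, a lower number that less compound is needed), compound 1 gives "not determined" (no result reported), and compound 2 gives "not determined" (no result reported), so neither contributes a number. Compound 3 `OC[C@@]12CN[C@@H]([C@H](n3cnc4c(NCc5cccc(I)c5)ncnc43)O1)[C@@H]2O` carries a larger substituent on the amine of the core. In this assay compound 3 gives > 3000 nM, which is a limit of the assay and not a measured number. Among the values shown, compound 3 stands at the limit of > 3000 nM in this assay, at which 1 of the 3 values shown sits. Compound 4 `CNC(=O)[C@@]12CN[C@@H]([C@H](n3cnc4c(NCc5cccc(I)c5)ncnc43)O1)[C@@H]2O` keeps that amine substituent and differs from compound 3 by methylcarbamoyl in place of hydroxymethyl on a saturated ring carbon. Going by the values given here, no pair of measured compounds shows what such a change does here, so the step is expected to be modest and its direction is uncertain, as an at least 1.2-fold lower number from compound 3 to compound 4 (0.07 log units; that floor lies within the scatter) expresses. Compound 4 is therefore estimated at about 2500 nM, with a likely range from 300 nM to 20000 nM, and a fair chance that this assay again reports only a limit.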

Compound 4, half-maximal effective concentration: > 3000 nM
Compound 4: only a limit was reported (the forecaster's own chance of this, stated with the estimate: 55%); at least 1.2-fold (0.07 log units) between middle value and limit.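

In this assay, going by these compounds alone, compound 3 and compound 4 both end at a limit of the assay, so no step between them can be read. The compounds shown leave open what methylcarbamoyl in place of hydroxymethyl on a saturated ring carbon does to the effect in this assay.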